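Hydroxymethyl in place of formyl on the chain

The source may report more compounds than this note shows. Statements on the series, on what has been measured and on what is new or still open speak of the compounds shown alone.

Compound 1, `O=Cc1ccc(-c2cnc(C(=O)CCCCCCc3ccccc3)o2)nc1`, gives 2.2 nM in an assay for inhibition of Fatty-acid amide hydrolase 1 (Rattus norvegicus), using a Dixon plot; on this read-out higher numbers stand for weaker inhibition and lower numbers for stronger inhibition. Compound 2, `CSCc1ccc(-c2cnc(C(=O)CCCCCCc3ccccc3)o2)nc1`, gives 11.1 nM. Compound 3, `O=CCCCCc1cnc(C(=O)CCCCCCc2ccccc2)o1`, gives 14.6 nM.

Compound 3 is separated from compound 1 by a 6.6-fold higher number from compound 1 to compound 3 (0.82 log units; beyond the scatter), but from compound 2 only by a 1.3-fold higher number from compound 2 to compound 3 (0.12 log units; within the scatter). Compound 4, `O=C(CCCCCCc1ccccc1)c1ncc(CCCCCO)o1`, differs from compound 3 by hydroxymethyl in place of formyl on a saturated chain carbon, four bonds along the chain from an aromatic carbon. Going by the values given here, no measured step swaps a formyl group for a hydroxymethyl group. Among the compounds with values here, the only step that alters a formyl group is a 5.0-fold higher number from compound 1 to compound 2 (0.70 log units; beyond the scatter), where it sat on an aromatic carbon rather than on a chain. On that loose analogy a modest rise in this assay is expected, a 2.4-fold higher number from compound 3 to compound 4 (0.38 log units; beyond the scatter). Compound 4 is therefore estimated at 35 nM, with a range from 10 nM to 120 nM.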

Compound 4, inhibition constant: 10.1 nM
Compound 4: the middle estimate sits 3.5-fold (0.54 log units) above what was measured; low and high end bracket the measured number.
By their numbers in this assay, from the lowest: compound 1; then compounds 4, 2 and 3 (each within the scatter of the next).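

In this assay, hydroxymethyl in place of formyl at this chain end makes no difference that can be told from the scatter (a 1.4-fold lower number from compound 3 to compound 4 (0.16 log units; within the scatter)), so gaining a hydrogen-bond donor and losing the double bond leave the read-out where it was. The new compound also stays level with the ring-bearing compound 2 (a 1.1-fold lower number from compound 2 to compound 4 (0.04 log units; within the scatter)) but remains clearly short of compound 1 (a 4.6-fold higher number from compound 1 to compound 4 (0.66 log units; beyond the scatter)). Nothing available explains these results. As far as these compounds go, whether a carboxylic acid or an amine at this chain end would hold the same level remains open, as does the effect of a longer chain carrying the hydroxymethyl group.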